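The compounds below may be only part of what the source reports. "The series", "measured", "known", "first", "only" and "open" are said of these compounds alone.

Of the compounds shown here, three with a shared acyl-guanidine core have been measured in an assay for binding affinity to Melanocortin receptor 4 (Homo sapiens); a lower number here means a stronger inhibitor, a higher number a weaker inhibitor. Compound 1 `COc1ccc(Br)cc1CCc1c(F)cccc1C(=O)/N=C(\N)NCCCCN(C)Cc1ccccc1` gives 5.1 nM. Compound 2 `CCN(CC)CCCC(C)/N=C(/N)NC(=O)c1cccc(F)c1CCc1ccc2ccccc2c1` gives 690 nM, the second highest of the three numbers: compound 1 stands far lower, beyond the scatter, while compound 3 `CCN(CC)CCCC(C)/N=C(\NC(=O)c1cccc(F)c1CCc1cc(Br)ccc1OC)Nc1ccccc1` gives 4100 nM, higher than compound 2 and also beyond the scatter. Compound 4 `CCN(CC)CCCC(C)/N=C(/N)NC(=O)c1cccc(F)c1CCc1ccccc1Cl` has not yet been measured in this assay. It differs from compound 2 in one place (2-chlorophenyl in place of naphthalen-2-yl on a saturated chain carbon, two bonds along the chain from an aromatic carbon). Within the data shown here, no measured pair shows this change, so the expectation rests on compound 2 alone; the step from compound 2 to compound 4 is expected to be modest, a 1.7-fold higher number from compound 2 to compound 4 (0.24 log units; within the scatter), leaning toward a weaker binder. For compound 4 an inhibition constant of about 1200 nM is estimated, with a range from 350 nM to 4000 nM.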

Compound 4, inhibition constant: 26000 nM
Compound 4: middle estimate off by 22-fold (1.34 log units), on the low side; the whole stated range lies below it.
By their numbers in this assay, from the lowest: compound 1; then compound 2; then compound 3; then compound 4.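

In this assay, 2-chlorophenyl in place of naphthalen-2-yl gives a 38-fold higher number from compound 2 to compound 4 (1.58 log units; beyond the scatter) and so shows that binding is highly sensitive to which aromatic group sits at this place on the saturated chain carbon. Among these compounds, no earlier pair could show this, as none of them differed in one place only. No measurement at hand bears on why this step is so large.

From the compounds shown here alone, the change removes a ring and adds a chlorine together, so their separate contributions stay open. A plain phenyl group at this place would help separate the two.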